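This account rests on a few compounds, and the source may have more. Where it says the series, first, only, none or still open, it means among the compounds named here.

Measured so far in a functional assay on the whole organism (strain CD-1) with Mus musculus as the target, with a stated time of 2 h; a higher number here means that more compound is needed for the effect, a lower number that less compound is needed:
- compound 1, `Cc1cccc(N2CCN(C(=O)CN3C(=O)CC(C)(c4ccccc4)C3=O)CC2)c1`: "not active" (no number reported)
- compound 2, `CC1(c2ccccc2)CC(=O)N(CC(=O)N2CCN(c3cccc(Cl)c3)CC2)C1=O`: "not active" (no number reported)
- compound 3, `CC1(c2ccccc2)CC(=O)N(CC(=O)N2CCN(c3ccccc3)CC2)C1=O`: 300 mg/kg

For the measured compounds named here, compound 3 carries the only number; compound 1 and compound 2 came back without a number in this assay, each recorded as not active. Going by the values given here, no step between measured compounds can be computed.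

Compound 4, `CC1(c2ccccc2)CC(=O)N(CC(=O)N2CCN(c3ccc(Cl)c(Cl)c3)CC2)C1=O`, is unmeasured. Its difference from compound 3: 3,4-dichlorophenyl in place of phenyl on an amine nitrogen in a ring.

Expectation: compound 2 already gave no number in this assay, so the step from compound 3 to compound 4 is expected to run toward a higher minimum effective dose, with a sizeable chance that compound 4 likewise returns no number. Compound 4 is estimated at 600 mg/kg, within 250 mg/kg to 1500 mg/kg; the expected step is a 2.0-fold higher number from compound 3 to compound 4 (0.30 log units; within the scatter).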

Compound 4, minimum effective dose: "not active" (no number reported)
Compound 4 has no reported number here; no gap can be computed for the estimate.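

For the compounds shown here, compound 4, like compound 1 and compound 2, has no number, so no step from compound 3 to compound 4 can be read, and no evidence bears on this result. The compounds shown leave open whether any substituted phenyl retains a measurable minimum effective dose.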